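The source may report more compounds than this note shows. Statements on the series, on what has been measured and on what is new or still open speak of the compounds shown alone.

Measured in a functional assay on EA.hy 926 cells (Homo sapiens) for cytotoxicity, read by MTT assay, with stated times of 24 h and 12 h, tested at 50 uM; on this read-out higher numbers stand for a stronger effect at the one concentration tested and lower numbers for a weaker effect:

Compound 1, `COc1ccc(/C=C/C(=O)O)cc1OC(=O)c1nc(C)c(C)nc1C`, gives 160%
Compound 2, `CCOC(=O)/C=C/c1cc(OC)ccc1OC(=O)c1nc(C)c(C)nc1C`, gives 27.8%
Compound 3, `Cc1nc(C)c(C(=O)Oc2cccc(/C=C/C(=O)O)c2)nc1C`, gives 75.3%

Compound 1 and compound 3 share a core and differ in a single place: hydrogen in place of methoxy on an aromatic carbon. That change produced a number 84.7 percentage points lower from compound 1 to compound 3 (beyond the scatter). Compound 2 holds the lowest of the three numbers; compound 3 is its nearest neighbour and compound 1 the furthest, both beyond the scatter. How the core of compound 2 differs from that of compound 1 is not broken down here.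

Compound 4, `CCOC(=O)/C=C/c1ccccc1OC(=O)c1nc(C)c(C)nc1C`, remains to be measured in this assay. It stands to compound 2 as compound 3 stands to compound 1: hydrogen in place of methoxy on an aromatic carbon. The surroundings are not identical, however. In compound 1 the methoxy sits ortho to a large group and para to a 2-carboxyethenyl group, whereas in compound 2 it sits meta to a 2-(ethoxycarbonyl)ethenyl group and para to a large group, so this is the same kind of change rather than the same change. Among the compounds with values here, the one measured instance of this kind of change, a number 84.7 percentage points lower from compound 1 to compound 3 (beyond the scatter), was large and pointed downward. Compound 2 starts low, at 27.8%, which leaves little room for a step of comparable size in the same direction. Because compound 2 already stands at 27.8%, only a modest downward step is therefore expected, a number 9.8 percentage points lower from compound 2 to compound 4 (within the scatter). For compound 4 the expected value in this assay is 18%, estimated to lie between 4% and 50%.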

Compound 4, a percentage reported as activity, at one concentration (the size of the read-out at that concentration, not a potency): 36.9%
Estimate against measurement, compound 4: 18.9 percentage points below; measured number inside the range.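

In this assay, replacing methoxy with hydrogen does not behave as one fixed effect across the series: on the core of compound 2 it gives a number 9.1 percentage points higher from compound 2 to compound 4 (within the scatter), and set beside the earlier step, the two cores clearly part: the same change on two cores in this assay, a number 84.7 percentage points lower (beyond the scatter) from compound 1 to compound 3 and a number 9.1 percentage points higher (within the scatter) from compound 2 to compound 4, 93.8 percentage points apart, beyond the scatter of two such steps The large downward step seen on the core of compound 1 therefore does not transfer to the core of compound 2, and on present data this change has to be read separately for each core. This does not show which structural feature separates the two outcomes: the cores differ both in the side chain, a 2-carboxyethenyl group against a 2-(ethoxycarbonyl)ethenyl group, and in where the methoxy stands, and a single pair per core cannot separate these or support a rule for any further core.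

The compounds shown leave open whether the side chain or the place of the methoxy decides the size of the step, which would take a pair varying only one of the two. Also open, going by these compounds, is how a hydroxyl or an ethoxy in the methoxy's place, or an amide in place of the ethyl ester, would fare on either core.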